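From cyclopropylmethoxy to ethoxy on a shared core

This account rests on a few compounds, and the source may have more. Where it says the series, first, only, none or still open, it means among the compounds named here.

Measured in an ADME assay on cells (Hepatocyte, Mus musculus) for metabolic stability, read by LC-MS, with a stated time of 180 min, tested at 1 uM (a higher number here means faster removal of the compound, a lower number slower removal), so far:
compound 1 `O=C(O)Cn1nc(Cn2cc3cc(OCC4CC4)c(Cl)cc3n2)c2ccccc2c1=O` gives < 40 mL/min/kg as a limit
compound 2 `C[C@H](C(=O)O)n1nc(Cn2cc3cc(OCC4CC4)c(Cl)cc3n2)c2ccccc2c1=O` gives 63.3 mL/min/kg as a number

For compound 1 the reading is only a limit (the limit of < 40 mL/min/kg in this assay, at which 1 of the 2 values shown sits) and not a number. Compound 3 `CCOc1cc2cn(Cc3nn(CC(=O)O)c(=O)c4ccccc34)nc2cc1Cl` carries methyl in place of cyclopropyl on a saturated chain carbon bound to an oxygen on an aromatic ring so cyclopropylmethoxy becomes ethoxy. Among the compounds with values here, the one measured step (an at least 1.5-fold higher number from compound 1 to compound 2 (0.19 log units; that floor lies within the scatter)) lies elsewhere in the molecule and its floor stays within the scatter, so it gives only loose guidance. No step beyond the scatter is therefore expected in this assay for this change. The expected step is small (a step that the limit leaves unreadable from compound 1 to compound 3) and may be seen only as a limit. For compound 3 the estimated value is 30 mL/min/kg with an expected range from 15 mL/min/kg to 55 mL/min/kg in this measurement.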

Compound 3, clearance: 128 mL/min/kg
Compound 3: middle estimate off by 4.3-fold (0.63 log units), on the low side; the measured number lies above the stated range.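

In this assay the change from cyclopropylmethoxy to ethoxy gives an at least 3.2-fold higher number from compound 1 to compound 3 (0.50 log units; beyond the scatter) and so clears the scatter. Within the data shown here, it is the first step here to do so, showing that this position on the shared core can move clearance, whereas the earlier step lay elsewhere in the molecule and its floor stayed within the scatter. The true size of the step stays unknown, since it is only a floor: the limit of < 40 mL/min/kg in this assay, at which 1 of the 3 values shown sits.

Open, from the compounds shown here alone, is whether a longer chain such as propoxy would read nearer compound 1 or compound 3. Also open, going by these compounds, is whether the same change would carry over to the core of compound 2.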